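The compounds below may be only part of what the source reports. "The series", "measured", "known", "first", "only" and "open" are said of these compounds alone.

Compound 1 `COc1ccc(-c2cc(=O)c3c(OC)cc(OC)cc3[nH]2)cc1` carries no sulfonyl group on its core. In a functional assay on HepG2 cells (Homo sapiens) for antiproliferative activity, with a stated time of 72 h (a lower number here means that less compound is needed, a higher number that more compound is needed for the effect), compound 1 reaches only the limit > 31100 nM, so no number is known for it. Compound 2 `COc1ccc(-c2cc(=O)c3c(OC)cc(OC)cc3n2S(=O)(=O)c2cc(F)c(F)c(F)c2)cc1` adds a 3,4,5-trifluorophenyl on a sulfonyl sulfur joined to an aromatic nitrogen. In this assay compound 2 likewise stops at the limit > 65500 nM. Compound 3 `COc1ccc(-c2cc(=O)c3c(OC)cc(OC)cc3n2S(=O)(=O)c2cc(Cl)cc(Cl)c2O)cc1` carries a 3,5-dichloro-2-hydroxyphenyl on that sulfonyl sulfur. For compound 3 this assay again gives only the limit > 37900 nM. The step that the two limits leave unreadable from compound 2 to compound 3 therefore cannot be read. All three values are limits (the limit of > 31100 nM in this assay, at which 1 of the 3 values shown sits, (the limit of > 37900 nM in this assay, at which 1 of the 3 values shown sits), (the limit of > 65500 nM in this assay, at which 1 of the 3 values shown sits)), so compound 3 stands level with the others as far as these limits can show. Compound 4 `COc1ccc(-c2cc(=O)c3c(OC)cc(OC)cc3n2S(=O)(=O)c2ccc(Br)cc2)cc1` differs from compound 3 by 4-bromophenyl in place of 3,5-dichloro-2-hydroxyphenyl on a sulfonyl sulfur. For the measured compounds named here, no measured step shows what exchanging one ring on the sulfonyl sulfur does; every value so far is a limit. The expectation for compound 4 is therefore another limit rather than a number, with an estimate of 60000 nM in a range from 15000 nM to 250000 nM. The step that the limit leaves unreadable from compound 3 to compound 4 that this estimate means is expected to stay within the scatter, as far as a limit can tell.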

Compound 4, half-maximal effective concentration: 16300 nM
Compound 4: middle estimate off by 3.7-fold (0.57 log units), on the high side; the range from low to high includes it.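

For the compounds shown here, compound 4 is the first compound here to give a number in this assay rather than a limit, which shows that the ring on the sulfonyl sulfur can change how much compound is needed. Placing 4-bromophenyl on that sulfur gives an at least 2.3-fold lower number from compound 3 to compound 4 (0.36 log units; beyond the scatter) and also an at least 4.0-fold lower number from compound 2 to compound 4 (0.60 log units; beyond the scatter), and both steps are true floors, so the real differences may be larger. The comparison with the core lacking a sulfonyl group is less clear, with an at least 1.9-fold lower number from compound 1 to compound 4 (0.28 log units; that floor lies within the scatter), and nothing measured here explains the effect of the ring.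

On these data alone, compound 4 differs from compound 3 in the two chlorines, the hydroxy group and the bromine at once, so the change that matters remains open. As far as these compounds go, how a ring on the sulfonyl sulfur carrying an amine or a carboxylic acid would behave also remains open.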